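The source may report more compounds than this note shows. Statements on the series, on what has been measured and on what is new or still open speak of the compounds shown alone.

Measured compounds in a functional assay on HT-29 cells (Homo sapiens) for inhibition, read by MTT assay, with a stated time of 72 h; on this read-out lower numbers stand for stronger inhibition of growth and higher numbers for weaker inhibition of growth:
compound 1 `CC(C)(C)c1ccc(CNCCNS(=O)(=O)c2cc(C(F)(F)F)cc(C(F)(F)F)c2)cc1`: 14000 nM
compound 2 `CC(C)(C)c1ccc(CNCCCNS(=O)(=O)c2cc(C(F)(F)F)cc(C(F)(F)F)c2)cc1`: 2000 nM
compound 3 `O=S(=O)(NCCCNCc1ccc(C(F)(F)F)cc1)c1cc(C(F)(F)F)cc(C(F)(F)F)c1`: 2900 nM

Compound 2 carries the three-carbon chain between the two nitrogens; compound 1 has the shorter chain and gives a clearly higher number in this assay, the two values lying well apart. Compound 2 and compound 3 sit within the scatter of each other: the step of a 1.5-fold higher number from compound 2 to compound 3 (0.16 log units; within the scatter) is too small to read as a change.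

Compound 4 `O=S(=O)(NCCCNCc1ccccc1)c1cc(C(F)(F)F)cc(C(F)(F)F)c1` is not yet measured. Relative to compound 2 it differs only by hydrogen in place of tert-butyl on an aromatic carbon. Going by the values given here, the one measured step that touches this position, from compound 2 to compound 3, swapped one group for another of similar bulk and left the number essentially unchanged. Among the compounds with values here, no measured pair removes the group altogether, so the effect of the bare phenyl is not covered by the present data. The working expectation is a modest rise in the number for compound 4, because the step of a 1.5-fold higher number from compound 2 to compound 3 (0.16 log units; within the scatter) shows the position tolerates exchange but gives no evidence that it tolerates loss.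

Compound 4 is therefore estimated at 5000 nM in this assay, with a range of 2000 nM to 14000 nM, meaning an expected step of a 2.5-fold higher number from compound 2 to compound 4 (0.40 log units; beyond the scatter).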

Compound 4, concentration for 50% growth inhibition: 15000 nM
The estimate for compound 4 lay 3.0-fold (0.48 log units) below the measured number; measured number outside the range, above it.
By their numbers in this assay, from the lowest: compounds 2 and 3 (each within the scatter of the next); then compounds 1 and 4 (each within the scatter of the next).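

In this assay, the aromatic carbon carrying tert-butyl proves to be a place where the substituent matters: removing the group gives a 7.5-fold higher number from compound 2 to compound 4 (0.88 log units; beyond the scatter), whereas exchanging it for trifluoromethyl gave only a 1.5-fold higher number from compound 2 to compound 3 (0.16 log units; within the scatter). The pair with trifluoromethyl points the same way, with a 5.2-fold higher number from compound 3 to compound 4 (0.71 log units; beyond the scatter), so in both available pairs the substituted benzyl goes with stronger inhibition of growth than the plain benzyl. The earlier compounds showed that one group could stand in for the other at this place, and these pairs add that hydrogen does not serve as a replacement for either; no measurement shown here accounts for this difference.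

On these data alone, whether a methyl, a chlorine, a methoxy or a carboxylic acid on the same aromatic carbon would stay with tert-butyl and trifluoromethyl or fall with hydrogen remains open. Also open is whether the same loss would appear on the shorter chain of compound 1, as the plain benzyl is shown only on the three-carbon chain.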